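This account rests on a few compounds, and the source may have more. Where it says the series, first, only, none or still open, it means among the compounds named here.

- compound 1 `CCCOc1ccc([C@@H]2CC(=O)c3cc(CC=C(C)C)c(OC)cc3O2)cc1`: 63%
- compound 2 `COc1ccc([C@@H]2C/C(=N/OCc3cn(-c4ccc(C#N)cc4)nn3)c3cc(CC=C(C)C)c(OC)cc3O2)cc1`: 50%
- compound 3 `COc1cc2c(cc1CC1OC1(C)C)C(=O)C[C@@H](c1ccc(O)cc1)O2`: 97%

In a functional assay on HCT-116 cells (Homo sapiens) for inhibition, read by sulforhodamine B assay, with a stated time of 48 h, tested at 50 uM (on this read-out lower numbers stand for less inhibition of growth and higher numbers for more inhibition of growth at the one concentration tested), compound 1 gives 63% and stands second highest of the three numbers. Compound 2 lies below it and compound 3 above it, both gaps beyond the usual scatter.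

The next compound to be tested is compound 4 `CCCCOc1ccc([C@@H]2CC(=O)c3cc(CC=C(C)C)c(OC)cc3O2)cc1`. It differs from compound 1 by methyl in place of hydrogen on a saturated chain carbon, three bonds along the chain from an oxygen on an aromatic ring, so that propyl becomes butyl. For the measured compounds named here, no pair of measured compounds differs in one place only, so the data offer no direct guide to the size of such a step. In this assay no step beyond the scatter is expected, in either direction, and the expectation starts from compound 1 at 63%. The expected change is a number 1 percentage points higher from compound 1 to compound 4 (within the scatter). For compound 4 the estimated value is 64%, with an expected range from 50% to 78%.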

Compound 4, percent growth inhibition at one concentration: 60%
Compound 4: the middle estimate sits 4 percentage points above what was measured, within the range that was stated.
By their numbers in this assay, from the lowest: compounds 2, 4 and 1 (each within the scatter of the next, the first and the last beyond it); then compound 3.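

In this assay, for the compounds shown here, the change from propyl to butyl gives the first comparison in this set between compounds that differ in one place only: a number 3 percentage points lower from compound 1 to compound 4 (within the scatter). Methyl in place of hydrogen on a saturated chain carbon, three bonds along the chain from an oxygen on an aromatic ring, therefore leaves the growth inhibition at the one concentration tested unchanged within the scatter, so propyl and butyl cannot be told apart here. No other measurement bears on this result.

From the compounds shown here alone, it remains open whether a longer chain such as hexyl, or a chain ending in an amine or a carboxylic acid, would stay within the scatter of compound 1 at this place. One step at one concentration also leaves open whether butyl and propyl would remain indistinguishable at other concentrations.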